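This account rests on a few compounds, and the source may have more. Where it says the series, first, only, none or still open, it means among the compounds named here.

Measured so far in an ADME assay on microsomes from liver (Homo sapiens) for metabolic stability, read by LC-MS, using NADPH, with a stated time of 30 min, tested at 0.1 uM; on this read-out higher numbers stand for a more stable compound and lower numbers for a less stable compound:
- compound 1 `O=S(=O)(NCC1COC1)c1cccc(-c2ccc3nccc(-c4ccncc4)c3n2)c1`: 2%
- compound 2 `O=S(=O)(NCCN1CCCC1)c1cccc(-c2ccc3nccc(-c4ccnc(C(F)(F)F)c4)c3n2)c1`: 14%

Compound 1 at 2% is the lower of the two numbers. Compound 2 at 14% stands higher, and that gap lies beyond the usual scatter. These two compounds differ in more than one place, so their gap isolates no single change.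

The next compound is compound 3 `CS(=O)(=O)Nc1cccc(-c2ccc3nccc(-c4ccncc4)c3n2)c1`, which has methanesulfonamido in place of ((oxetan-3-yl)methyl)sulfamoyl on an aromatic carbon of a six-membered aromatic ring of carbon only, meta to a large group (methanesulfonamido in place of ((oxetan-3-yl)methyl)sulfamoyl on an aromatic carbon). The core of compound 1 is kept. Among the compounds with values here, no measured pair shows this exchange, so the expectation rests on little. With compound 1 at 2% there is hardly any room to fall, and any movement is more likely upward. The estimated change is small, a number 4 percentage points higher from compound 1 to compound 3 (within the scatter), and is expected to stay within the scatter in this assay. For compound 3 the estimate is 6% with an expected range from 1% to 25% for the measurement.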

Compound 3, percent of the compound remaining: 59%
Estimate against measurement, compound 3: 53 percentage points below; measured number above the stated range.
By their numbers in this assay, from the lowest: compound 1; then compound 2; then compound 3.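

On the aromatic carbon of the six-membered aromatic ring of carbon only, meta to a large group, methanesulfonamido in place of ((oxetan-3-yl)methyl)sulfamoyl gives in this assay a number 57 percentage points higher from compound 1 to compound 3 (beyond the scatter) with the core of compound 1 kept. Within the data shown here, this is the first step that isolates one place, and it shows that the group at this position alone can move the percent remaining by a large amount, which the gap between compound 1 and compound 2 could not show. The exchange removes a four-membered non-aromatic ring and lowers the heavy-atom count of the group from 9 to 5, but nothing measured here ties the step to either feature or gives a reason for it.

Still open, going by these compounds, is whether the step follows from losing the ring, from shortening the group, or from joining the sulfonyl unit to the aromatic ring through nitrogen instead of sulfur; a methylsulfamoyl group or an acetamido group at this position would help separate these. Also open, on these data alone, is whether the same exchange would give a comparable step on compound 2, which carries a trifluoromethyl group and a pyrrolidine-bearing chain.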